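This account rests on a few compounds, and the source may have more. Where it says the series, first, only, none or still open, it means among the compounds named here.

Compound 1 `O=C(CCl)Nc1ccc(SCC(=O)Nc2ccc(Cl)cn2)cc1`: 2500 nM; compound 2 `O=C(CCl)Nc1ccc(SCC(=O)Nc2ccc(Cl)cc2)cc1`: limit, > 80000 nM; compound 3 `O=C(CCl)Nc1ccc(SCC(=O)Nc2ccccn2)cc1`: 7800 nM.

In a functional assay on HeLa cells (Homo sapiens) for antiproliferative activity, read by MTT assay, with a stated time of 48 h (on this read-out higher numbers stand for weaker inhibition and lower numbers for stronger inhibition), compound 3 gives 7800 nM, the highest of the two numbers given; compound 1 sits a 3.1-fold higher number from compound 1 to compound 3 (0.49 log units; beyond the scatter) away. For compound 2 this assay reports only a limit, > 80000 nM, which is the limit of > 80000 nM in this assay, at which 1 of the 3 values shown sits. Compound 4 `C=CC(=O)Nc1ccc(SCC(=O)Nc2ccccn2)cc1` differs from compound 3 by vinyl in place of chloromethyl on a carbonyl carbon. Going by the values given here, none of the measured steps touches this position: the steps of an at least 32-fold higher number from compound 1 to compound 2 (1.50 log units; beyond the scatter) and an at least 10-fold lower number from compound 2 to compound 3 (1.01 log units; beyond the scatter) change the group on the amide-type nitrogen, and a 3.1-fold higher number from compound 1 to compound 3 (0.49 log units; beyond the scatter) a chloro on an aromatic carbon. Among the compounds with values here, with no direct precedent, a modest rise in this assay is expected, a 1.5-fold higher number from compound 3 to compound 4 (0.19 log units; within the scatter). Compound 4 is estimated at 12000 nM, between 3000 nM and 50000 nM.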

Compound 4, half-maximal inhibitory concentration: > 80000 nM
Compound 4: a limit, no number; the forecaster's own chance of this, stated with the estimate: 10%; at least 6.6-fold (0.82 log units) between middle value and limit.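

Going by these compounds alone, the earlier compounds all carried chloromethyl on the carbonyl carbon, so they showed only that the group on the amide-type nitrogen and the aromatic chloro matter. With vinyl in place of chloromethyl, and nothing else changed, the series shows an at least 10-fold higher number from compound 3 to compound 4 (1.01 log units; beyond the scatter), so this position alone can carry a large step in this assay. Compound 4 gives only a limit, and it shares that limit with compound 2: the limit of > 80000 nM in this assay, at which 2 of the 4 values shown sit.

The compounds shown leave open how far beyond this limit compound 4 lies. They also leave open whether a bromomethyl or a plain methyl group on the carbonyl carbon would behave like chloromethyl or like vinyl.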